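Isopropyl for propyl on compound 1

The source may hold more compounds than are shown below. What is called first, only, known or untested is meant among the compounds shown, and "the series" means these compounds.

In a physicochemical assay for lipophilicity, read by HPLC, using the shake flask method (a lower number here means a more polar compound, a higher number a more lipophilic compound), compound 1 `CCC/C(=N\C#N)N(C)Cc1ccc(Cl)nc1` gives 1.55 and stands within the scatter of both measured relatives, compound 2 `C/C(=N\C#N)N(Cc1ccc(Cl)nc1)C(C)C` with 1.46 and compound 3 `CCCN(Cc1ccc(Cl)nc1)/C(C)=N/C#N` with 1.62 in the same measurement. Compound 4 `CC(C)/C(=N\C#N)N(C)Cc1ccc(Cl)nc1` is still unmeasured. The change isopropyl in place of propyl on a carbon with a double bond to nitrogen puts isopropyl in place of propyl on a carbon with a double bond to nitrogen. Among the measured compounds shown here, only one measured step bears on this: propyl in place of isopropyl on an amine nitrogen gives a number 0.16 log units higher from compound 2 to compound 3 (within the scatter) at a different place and in the opposite sense. No shift beyond the scatter is therefore expected in this assay for this change. The estimated step is a number 0.08 log units lower from compound 1 to compound 4 (within the scatter) and thus small. Compound 4 is expected at 1.47 within an estimated range from 1.2 to 1.75 for this measurement.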

Compound 4, partition coefficient: 1.39
The estimate for compound 4 lay 0.08 log units above the measured number, and the stated range covers the measured number.
By their numbers in this assay, from the lowest: compounds 4, 2, 1 and 3 (each within the scatter of the next).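

In this assay the carbon with a double bond to nitrogen now has a measured step of its own, with isopropyl in place of propyl giving (a number 0.16 log units lower from compound 1 to compound 4 (within the scatter)). Swapping these two chains at this place thus stays within the scatter, as the swap on an amine nitrogen did. No measurement on hand bears on the cause of this step.

The compounds shown leave open whether a longer chain such as butyl, or a cyclopropyl ring, at this same place would move the number beyond the scatter.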